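A Dihydroxyphenyl Replacement Weighed Against a Dimethoxy Step

The source may report more compounds than this note shows. Statements on the series, on what has been measured and on what is new or still open speak of the compounds shown alone.

Compound 1, `O=C1N=C(NN2Cc3ccccc3N=C2c2ccccc2)S/C1=C/c1ccc(Br)cc1`, in a functional assay on A549 cells (Homo sapiens) for cytotoxicity, read by MTT assay, with a stated time of 4 h (a lower number here means a stronger inhibitor, a higher number a weaker inhibitor), gives 21300 nM.
Compound 2, `COc1ccc(/C=C2/SC(NN3Cc4ccccc4N=C3c3ccccc3)=NC2=O)cc1OC`, in this assay gives 44700 nM.
Compound 3, `O=C(CNc1ccc(Br)cc1)Nn1c(-c2ccccc2)nc2ccccc2c1=O`, in this assay gives 25000 nM.

Compound 2 has the highest number of the three in this assay. Going by the values given here, its gap to compound 3 lies within the scatter, so the two cannot be set in order; its gap to compound 1 lies beyond it, and that is the one measured step with a change at the same place: a 2.1-fold higher number from compound 1 to compound 2 (0.32 log units; beyond the scatter).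

Compound 4, `O=C1N=C(NN2Cc3ccccc3N=C2c2ccccc2)S/C1=C/c1ccc(O)cc1O`, is not yet measured. It differs from compound 2 by 2,4-dihydroxyphenyl in place of 3,4-dimethoxyphenyl on a double-bonded chain carbon bound to a double-bonded ring carbon. Among the compounds with values here, the only step that bears on it is the one from compound 1 to compound 2, which exchanged groups on that same carbon and gave a modest weakening. Within the data shown here, no measured pair shows what free hydroxyls do here, and compound 3 carries a different core, so it offers no guidance for this exchange.

Because the step of a 2.1-fold higher number from compound 1 to compound 2 (0.32 log units; beyond the scatter) was only modest, a step of similar or smaller size is expected for compound 4, in either direction. The step from compound 2 to compound 4 is estimated as a 1.3-fold lower number from compound 2 to compound 4 (0.11 log units; within the scatter). Compound 4 is therefore expected to give about 35000 nM in this assay, within a range from 15000 nM to 90000 nM.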

Compound 4, half-maximal inhibitory concentration: 3220 nM
The estimate for compound 4 lay 11-fold (1.04 log units) above the measured number, outside the stated range (below it).
By their numbers in this assay, from the lowest: compound 4; then compounds 1, 3 and 2 (each within the scatter of the next, the first and the last beyond it).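

In this assay, the exchange of 3,4-dimethoxyphenyl for 2,4-dihydroxyphenyl gives a 14-fold lower number from compound 2 to compound 4 (1.14 log units; beyond the scatter) and so counts as a large step, whereas a 2.1-fold higher number from compound 1 to compound 2 (0.32 log units; beyond the scatter) was only modest; the group on the double-bonded chain carbon bound to a double-bonded ring carbon can therefore shift the number much further than the earlier pair showed. The same entering group also gives a 6.6-fold lower number from compound 1 to compound 4 (0.82 log units; beyond the scatter) against 4-bromophenyl, so 2,4-dihydroxyphenyl has the lowest number of the three groups seen at this place, and it brings 2 hydrogen-bond donors where 3,4-dimethoxyphenyl carried 0. Nothing given here accounts for the size of this drop.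

The step changes two things at once, the kind of oxygen substituent and where the two substituents stand on the ring, so the compounds shown cannot separate one from the other. A 3,4-dihydroxyphenyl or a 2,4-dimethoxyphenyl group would pull these apart, while a single 4-hydroxyphenyl group would test whether one hydroxyl is enough and a 4-aminophenyl group whether another donor-bearing substituent serves as well.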